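Swapping the Fluorophenyl Arm of a Shared Core

The source may hold more compounds than are shown below. What is called first, only, known or untested is meant among the compounds shown, and "the series" means these compounds.

Measured compounds:
compound 1 `Oc1ccc(-c2cc(-c3ccc(F)cc3)cc(-c3cccc(O)c3)n2)cc1` — 15200 nM
compound 2 `Oc1ccc(-c2cc(-c3ccc(F)cc3)cc(-c3ccc(O)cc3)n2)cc1` — 6030 nM

Both were tested in a functional assay on DU-145 cells (Homo sapiens) for inhibition; a lower number here means a stronger inhibitor, a higher number a weaker inhibitor. Among the measured compounds shown here, compound 2 gives the lowest of the two numbers; its nearest neighbour is compound 1, and the single measured step is a 2.5-fold lower number from compound 1 to compound 2 (0.40 log units; beyond the scatter). Compound 3 `Oc1ccc(-c2cc(-c3ccccc3C(F)(F)F)cc(-c3ccc(O)cc3)n2)cc1` differs from compound 2 by 2-(trifluoromethyl)phenyl in place of 4-fluorophenyl on an aromatic carbon. For the measured compounds named here, this change sits at a position no measured step has touched: the step from compound 1 to compound 2 concerns the hydroxyphenyl groups and says nothing about the group opposite the ring nitrogen. There is thus no measured basis for predicting a direction or a size for this assay. The expected outcome is simply the step of a 1.0-fold lower number from compound 2 to compound 3 (0.00 log units; within the scatter), which should be read as no clear change beyond the scatter, with a wide range to allow for surprise. The estimate for compound 3 is 6000 nM, between 2000 nM and 20000 nM.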

Compound 3, half-maximal inhibitory concentration: > 50000 nM
Compound 3: a limit, no number; the forecaster's own chance of this, stated with the estimate: 10%; at least 8.3-fold (0.92 log units) between middle value and limit.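

In this assay compound 3 gives > 50000 nM, which is a limit of the assay and not a number. Putting 2-(trifluoromethyl)phenyl in place of 4-fluorophenyl still gives a readable step, an at least 8.2-fold higher number from compound 2 to compound 3 (0.91 log units; beyond the scatter), so the group opposite the ring nitrogen, which the earlier step between the hydroxyphenyl isomers never touched, matters for inhibition in these cells, and this change weakens it. The step is only a minimum, and its true size lies out of reach: the limit of > 50000 nM in this assay, at which 1 of the 3 values shown sits.

With a single change at this position, the compounds shown do not separate the trifluoromethyl group itself from its place on the phenyl ring. A 4-(trifluoromethyl)phenyl or a 2-fluorophenyl group would pull these two apart, and a plain phenyl or a 4-aminophenyl group would show whether anything here can improve on compound 2.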